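This account rests on a few compounds, and the source may have more. Where it says the series, first, only, none or still open, it means among the compounds named here.

Measured compounds in an ADME assay on isolated protein for inhibition of Amine oxidase [flavin-containing] B (Homo sapiens); on this read-out higher numbers stand for weaker inhibition and lower numbers for stronger inhibition:
- compound 1, `C#CCNC1CCc2c(SCc3cccc(C)c3)cccc21`: > 100000 nM
- compound 2, `C#CCNC1CCc2c(SCCc3ccc(F)c(F)c3)cccc21`: "not determined" (no result reported)
- compound 3, `C#CCNC1CCc2c(SCc3ccc(Br)cc3)cccc21`: 488 nM

The value for compound 1 is a limit of this assay, not a number (the limit of > 100000 nM in this assay, at which 1 of the 3 values shown sits). Among the compounds with values here, for compound 2 no number has been reported in this assay, so its standing on the scale cannot be placed among the others; compound 3 is the only member with a definite number.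

The step under consideration leads to compound 4, `C#CCNC1CCc2c(SCCc3ccc(Cl)c(Cl)c3)cccc21`, not yet measured in this assay. The change is 3,4-dichlorophenyl in place of 3,4-difluorophenyl on a saturated chain carbon, two bonds along the chain from a sulfur.

Of the measured steps, only an at least 200-fold lower number from compound 1 to compound 3 (2.31 log units; beyond the scatter) bears on it, and only loosely: it also exchanges one substituted phenyl for another on a chain carbon attached through sulfur, and the halogenated phenyl gave the definite number. That step changes both the substituent and its position on the ring, whereas the step to compound 4 keeps the 3,4-pattern and swaps fluorine for chlorine. With no number for compound 2, no direction can be taken from this series itself; the expectation therefore rests on compound 3 alone.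

Compound 4 is estimated to give about 300 nM in this assay, with a broad range from 30 nM to 3000 nM.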

Compound 4, half-maximal inhibitory concentration: 2820 nM
The estimate for compound 4 lay 9.4-fold (0.97 log units) below the measured number; measured number inside the range.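

In this assay compound 4 gives 2820 nM, but compound 2 carries no number, so the step from compound 2 to compound 4 cannot be read. Nothing shown bears on this result. The compounds shown leave open how 3,4-dichlorophenyl and 3,4-difluorophenyl compare on this chain in this assay.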